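The source may hold more compounds than are shown below. What is called first, only, known or untested is meant among the compounds shown, and "the series" means these compounds.

Measured in a functional assay on thoracic aorta (Rattus norvegicus, strain Wistar), with a stated time of 15 min; a higher number here means that more compound is needed for the effect, a lower number that less compound is needed:
- compound 1 `COc1ccc(OC)c(CNC(=O)NS(=O)(=O)c2ccc(Cl)cc2)c1`: > 300000 nM
- compound 2 `COc1ccc(OC)c(CNC(=O)NS(=O)(=O)c2ccc(C)cc2)c1`: > 300000 nM
- compound 3 `COc1ccc(OC)c(CNC(=O)NS(=O)(=O)c2ccccc2)c1`: > 300000 nM

Each of these entries is a limit of the assay and not a number. Compound 3 therefore has no exact place in the series, and the same is true of the other two: the limit of > 300000 nM in this assay, at which 3 of the 3 values shown sit.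

Compound 4 `COc1ccc(OC)c(CNC(=O)N(C)S(=O)(=O)c2ccccc2)c1` differs from compound 3 by methyl in place of hydrogen on an amide-type nitrogen. The measured steps concern a different site, an aromatic carbon: a step that the two limits leave unreadable from compound 1 to compound 2, a step that the two limits leave unreadable from compound 1 to compound 3 and a step that the two limits leave unreadable from compound 2 to compound 3. They give no size to carry over, so they offer only weak guidance. With no measured sign of activity in this small set, no step beyond the scatter in this assay is expected, and no direction can be favoured. The expected step is a number no higher from compound 3 to compound 4 (the limit leaves the size open). A report of only a limit again seems the likeliest outcome. For compound 4 the estimated value is 300000 nM, with an expected range from 100000 nM to 600000 nM.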

Compound 4, half-maximal effective concentration: 21300 nM
The estimate for compound 4 lay 14-fold (1.15 log units) above the measured number; measured number below the stated range.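

Putting methyl in place of hydrogen on the amide-type nitrogen gives, in this assay, an at least 14-fold lower number from compound 3 to compound 4 (1.14 log units; beyond the scatter). This nitrogen is therefore a site where a single small change produces a readable effect, whereas the steps among compound 1, compound 2 and compound 3, all at the aromatic carbon, cannot be read. Compound 4 is the only compound shown with an exact number, while the others remain at a limit of the assay: the limit of > 300000 nM in this assay, at which 3 of the 4 values shown sit.

Going by these compounds, it remains open whether an ethyl group or a longer chain on this nitrogen would lower the number further or raise it again. Also open is whether chloro or methyl on the aromatic carbon would change the number once the nitrogen carries methyl, as the compounds shown have those groups only with hydrogen there.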